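The compounds below may be only part of what the source reports. "The series", "measured", "known", "first", "only" and "open" are said of these compounds alone.

In an ADME assay on HEK293 cells (Homo sapiens) for cytotoxicity, with a stated time of 72 h (a lower number here means that less compound is needed, a higher number that more compound is needed for the effect), three compounds built on one shared core have been measured, and each result is a limit, not a number. Compound 1 `Cc1cc(NC(=O)Nc2cccc([N+](=O)[O-])c2)c2ccccc2n1` gives the limit > 25000 nM. Compound 2 `Cc1cc(NC(=O)Nc2cccc(C(N)=O)c2)c2ccccc2n1` gives the limit > 25000 nM. Compound 3 `Cc1cc(NC(=O)Nc2ccc(F)c(F)c2)c2ccccc2n1` gives the limit > 25000 nM, which places it with the others: the limit of > 25000 nM in this assay, at which 3 of the 3 values shown sit. Compound 4 `Cc1cc(NC(=O)Nc2cccc(F)c2)c2ccccc2n1` differs from compound 3 by hydrogen in place of fluoro on an aromatic carbon. Among the compounds with values here, the only measured single-place change is a step that the two limits leave unreadable from compound 1 to compound 2, so it offers no size to carry over. With compound 3 at the limit > 25000 nM, no step beyond the scatter is expected in this assay. The expected change is a number no higher from compound 3 to compound 4 (the limit leaves the size open). For compound 4 the estimate is 25000 nM, with an expected range of 10000 nM to 50000 nM.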

Compound 4, half-maximal effective concentration: > 25000 nM
Compound 4: only a limit was reported; the forecaster's own chance of this, stated with the estimate: 85%; the middle value sits exactly at the limit.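

Compound 4 also gives only a limit, as do compound 1, compound 2 and compound 3, so no step to compound 4 can be read: the limit of > 25000 nM in this assay, at which 4 of the 4 values shown sit.

The compounds shown leave open what concentration of any of them would produce the effect in this assay.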